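A smaller ring on compound 3

The source may hold more compounds than are shown below. What is called first, only, known or untested is meant among the compounds shown, and "the series" means these compounds.

Compound 1 `CC(C)S(=O)(=O)c1nn(C)cc1Nc1nc(Nc2ccc(C3CCN(C)CC3)cc2OC2CC2)ncc1Cl` gives 7 nM
Compound 2 `Cc1cc(Nc2ncc(Cl)c(Nc3cn(C)nc3S(=O)(=O)C(C)C)n2)c(OC(C)C)cc1C1CNC1` gives 60 nM
Compound 3 `Cc1cc(Nc2ncc(Cl)c(Nc3cn(C)nc3S(=O)(=O)C(C)C)n2)c(OC2CC2)cc1C1CCCN(C)C1` gives 3 nM

All three numbers come from a functional assay on KARPAS-299 cells (Homo sapiens) for inhibition, read by CellTiter-Glo, with a stated time of 96 h (on this read-out lower numbers stand for stronger inhibition and higher numbers for weaker inhibition), and compound 3 stands lowest of them, ahead of both others by more than the scatter. Compound 4 `Cc1cc(Nc2ncc(Cl)c(Nc3cn(C)nc3S(=O)(=O)C(C)C)n2)c(OC2CC2)cc1C1COC1` has oxetan-3-yl in place of 1-methylpiperidin-3-yl on an aromatic carbon. For the measured compounds named here, no measured pair shows this change alone, so any forecast is uncertain. A nitrogen-bearing ring sits at this place in all three measured compounds, and compound 3 at 3 nM leaves little room for a lower number. The expected step of a 10-fold higher number from compound 3 to compound 4 (1.00 log units; beyond the scatter) is therefore toward weaker inhibition, beyond the scatter. Compound 4 is expected at an estimated 30 nM within a range from 8 nM to 120 nM as its upper end.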

Compound 4, half-maximal inhibitory concentration: 19 nM
Beside the measured number, compound 4's estimate is 1.6-fold (0.20 log units) above it; measured number inside the range.
By their numbers in this assay, from the lowest: compound 3; then compound 1; then compound 4; then compound 2.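

In this assay, the step of a 6.3-fold higher number from compound 3 to compound 4 (0.80 log units; beyond the scatter) isolates a single change at this position: the smaller oxetan-3-yl, with oxygen as its ring hetero atom, replaces 1-methylpiperidin-3-yl. The swap weakens inhibition, yet compound 4 still gives 19 nM, so a ring nitrogen is not essential here for activity in the nanomolar range. No measurement shown explains the loss. The compounds shown leave open whether ring size or the change of hetero atom matters more. A tetrahydropyran-3-yl group, a six-membered ring containing oxygen, would help separate the two.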